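Aryl variation on a shared core: armyworm inhibition notes

This account rests on a few compounds, and the source may have more. Where it says the series, first, only, none or still open, it means among the compounds named here.

Measured so far in a functional assay on the whole organism for inhibition, with Mythimna separata as the target, with a stated time of 5 days; on this read-out lower numbers stand for an effect already at smaller amounts and higher numbers for an effect only at larger amounts of compound:
compound 1 `COc1c(F)c(F)cc(-c2nnc(COc3cnn(C(C)(C)C)c(=O)c3Cl)o2)c1F` gives > 300 ug/mL, a limit of the assay.
compound 2 `Cc1cc(C)cc(-c2nnc(COc3cnn(C(C)(C)C)c(=O)c3Cl)s2)c1` gives > 300 ug/mL, a limit of the assay.
compound 3 `Cc1cc(C)cc(-c2nnc(COc3cnn(C(C)(C)C)c(=O)c3Cl)o2)c1` gives > 300 ug/mL, a limit of the assay.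

Compound 3 therefore stands nowhere in particular: its reading is a limit and not a number, and the same holds for the two other entries, so no order among the three can be read off. All three measurements are the limit of > 300 ug/mL in this assay, at which 3 of the 3 values shown sit. For the measured compounds named here, no step between two measured compounds exists in this set, because each of them stops at the limit of > 300 ug/mL in this assay, at which 3 of the 3 values shown sit.

Compound 4 `CC(C)(C)n1ncc(OCc2nnc(-c3ccc(Cl)cc3)o2)c(Cl)c1=O` differs from compound 3 in one place: 4-chlorophenyl in place of 3,5-dimethylphenyl on an aromatic carbon. Going by the values given here, with every measured value a limit, the set gives no measured step to lean on for this change. The expectation is that the step that the limit leaves unreadable from compound 3 to compound 4 is none beyond the usual scatter, with compound 4 most likely again reaching only the limit. Compound 4 is estimated at 400 ug/mL, in the range 150 ug/mL to 1000 ug/mL, and the actual reading will settle this.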

Compound 4, half-maximal effective concentration: 1.9 ug/mL
Compound 4: the middle estimate sits 210-fold (2.32 log units) above what was measured, and the stated range ends above it.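

In this assay, placing 4-chlorophenyl instead of 3,5-dimethylphenyl on the aromatic carbon of the five-membered aromatic ring gives an at least 150-fold lower number from compound 3 to compound 4 (2.19 log units; beyond the scatter), which shows that the aryl group at this position can decide between a measurable reading and none on the shared core. As far as these compounds go, compound 3 gives > 300 ug/mL, which is a limit of the assay, so the step is a minimum and its full size remains unknown. Compound 4 is the only entry with a number rather than a limit, and no steps can be read among compound 1, compound 2 and compound 3, which all stand at one value: the limit of > 300 ug/mL in this assay, at which 3 of the 4 values shown sit.

This single change swaps the whole aryl group, so the compounds shown cannot separate the contribution of the chlorine from the loss of the two methyl groups, and unsubstituted phenyl, 4-methylphenyl or 4-methoxyphenyl would bear on that. Also open, from the compounds shown here alone, is whether 4-chlorophenyl gives a similar reading on the core of compound 2, and whether the chlorine can be exchanged for a bromine or a trifluoromethyl group.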